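Vero cell cytotoxicity notes on cinnamamide and oxazole esters

A few compounds are considered here, and "the series" means these few. Any claim that something is new, unique, unknown or untested is made for them only; others in the source may bear on it.

Measured compounds:
compound 1, `COC(=O)[C@H](CO)NC(=O)/C=C/c1ccc(OC)cc1`, 100%
compound 2, `COC(=O)[C@H](CO)NC(=O)/C=C/c1ccc(C)cc1`, 100%
compound 3, `COC(=O)c1coc(/C=C/c2ccc(OC)cc2)n1`, 99.6%

In an ADME assay on Vero cells (Chlorocebus sabaeus) for cytotoxicity, read by WST assay, tested at 50 ug/mL (a lower number here means a stronger effect, a higher number a weaker effect of the compound at the concentration tested), compound 1 gives 100%. Compound 2 differs from compound 1 by methyl in place of methoxy on an aromatic carbon. Compound 2 gives 100%; the step of no change at the digits printed from compound 1 to compound 2 (within the scatter). Compound 3 gives 99.6%; its values sit within the scatter of compound 1 and compound 2. The difference between the core of compound 3 and the core of compound 1 is not broken down here.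

Compound 4, `COC(=O)c1coc(/C=C/c2ccc(C)cc2)n1`, is not yet measured. It differs from compound 3 by methyl in place of methoxy on an aromatic carbon, the same change as from compound 1 to compound 2. Because no change at the digits printed from compound 1 to compound 2 (within the scatter), the step of a number 0.6 percentage points lower from compound 3 to compound 4 (within the scatter) is expected to be no larger than the scatter. Compound 4 is estimated at 99% in this assay, between 90% and 100%.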

Compound 4, a percentage reported as activity, at one concentration (the size of the read-out at that concentration, not a potency): 102%
Beside the measured number, compound 4's estimate is 3 percentage points below it; measured number above the stated range.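

In this assay, methyl in place of methoxy on an aromatic carbon gives a number 2.4 percentage points higher from compound 3 to compound 4 (within the scatter). Set beside the earlier step, the change carries from one core to the other with no difference that can be told from the scatter: the same change on two cores in this assay, no change at the digits printed (within the scatter) from compound 1 to compound 2 and a number 2.4 percentage points higher (within the scatter) from compound 3 to compound 4, 2.4 percentage points apart, within the scatter of two such steps. This holds only for these two cores and for the read-out at the single concentration tested, so it gives no potency and does not show that the change would behave alike on any other core.

As far as these compounds go, whether an amine, a carboxylic acid or trifluoromethyl on the same aromatic carbon would stay within the scatter remains open. So does the outcome of a longer chain in place of the methoxy.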